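Side chain change from compound 2 to compound 4

The compounds below may be only part of what the source reports. "The series", "measured", "known", "first", "only" and "open" are said of these compounds alone.

In a functional assay on BV-2 cells (Mus musculus) for inhibition, read by Griess assay, with a stated time of 24 h (on this read-out lower numbers stand for stronger inhibition and higher numbers for weaker inhibition), compound 2 (`C=CCc1ccc(OC)c(-c2cc(CCC)on2)c1`) gives > 200000 nM as a limit. Compound 1 (`CCCc1cc(-c2cc(Br)ccc2OC)no1`) gives > 200000 nM as a limit. Compound 3 (`C=CCc1ccc(O)c(-c2cc(CCC)on2)c1`) gives > 200000 nM as a limit. For the measured compounds named here, the series so far therefore rests on the limit of > 200000 nM in this assay, at which 3 of the 3 values shown sit, with no number yet.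

Compound 4 (`C=CCc1ccc(OC)c(-c2cc(COCC(=O)OCC)on2)c1`) carries (ethoxycarbonyl)methoxy in place of ethyl on a saturated chain carbon bound to an aromatic carbon, counted in full as (ethoxycarbonyl)methoxy in place of ethyl on a saturated chain carbon bound to an aromatic carbon here.

The measured steps a step that the two limits leave unreadable from compound 1 to compound 2 and a step that the two limits leave unreadable from compound 2 to compound 3 have no readable size, and neither changes this chain. In this assay only a modest move toward stronger inhibition is expected, and another limit remains likely. The expected step is an at least 1.3-fold lower number from compound 2 to compound 4 (0.12 log units; that floor lies within the scatter) in that direction. For compound 4 the estimated value is 150000 nM within an expected range of 40000 nM to 400000 nM in this assay.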

Compound 4, half-maximal inhibitory concentration: 25900 nM
Beside the measured number, compound 4's estimate is 5.8-fold (0.76 log units) above it; the whole stated range lies above it.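

For the compounds shown here, the change of ethyl to (ethoxycarbonyl)methoxy on this saturated chain carbon gives an at least 7.7-fold lower number from compound 2 to compound 4 (0.88 log units; beyond the scatter) in this assay, so this side chain is the first place where a change has a readable size. The earlier steps shown here, at the bromo position and at the methyl on oxygen, cannot be read. Compound 4 is the only compound here with a number rather than a limit: the limit of > 200000 nM in this assay, at which 3 of the 4 values shown sit.

Still open, from the compounds shown here alone, is whether a plain longer chain would give the same move, or whether the ether oxygen and ethoxycarbonyl are needed. A carboxylic acid or an amide in place of the ethoxycarbonyl would test the second point.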